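Benzylamine aryl swap: chloro expected near methoxy and bromo

This account rests on a few compounds, and the source may have more. Where it says the series, first, only, none or still open, it means among the compounds named here.

Three compounds have numbers in a functional assay on BE(2)-C cells (Homo sapiens) for inhibition, read by MTT assay, with a stated time of 72 h; on this read-out lower numbers stand for stronger inhibition of growth and higher numbers for weaker inhibition of growth:
compound 1, `O=S(=O)(NCCCNCc1ccccc1Cl)c1cc(C(F)(F)F)cc(C(F)(F)F)c1`, gives 15000 nM;
compound 2, `O=S(=O)(NCCCNCc1ccc(Br)cc1)c1cc(C(F)(F)F)cc(C(F)(F)F)c1`, gives 2700 nM;
compound 3, `COc1ccc(CNCCCNS(=O)(=O)c2cc(C(F)(F)F)cc(C(F)(F)F)c2)cc1`, gives 2800 nM.

Compound 3 stands second highest of the three numbers; its nearest neighbour is compound 2, with the step of a 1.0-fold higher number from compound 2 to compound 3 (0.02 log units; within the scatter) lying within the scatter, and its furthest is compound 1, from which a 5.4-fold lower number from compound 1 to compound 3 (0.73 log units; beyond the scatter) runs. Compound 4, `O=S(=O)(NCCCNCc1ccc(Cl)cc1)c1cc(C(F)(F)F)cc(C(F)(F)F)c1`, differs from compound 3 by chloro in place of methoxy on an aromatic carbon, on an aromatic carbon para to a large group. Among the compounds with values here, two measured steps bear on this change. The step of a 5.6-fold lower number from compound 1 to compound 2 (0.74 log units; beyond the scatter) and the step of a 5.4-fold lower number from compound 1 to compound 3 (0.73 log units; beyond the scatter) both moved the number in the same direction and by almost the same amount, so that the bromo and methoxy compounds sit together, as a 1.0-fold higher number from compound 2 to compound 3 (0.02 log units; within the scatter) shows. A chloro group on the same ring carbon is therefore expected to give no step beyond the scatter, and the estimate for compound 4 in this assay is 2700 nM, within 1200 nM to 6000 nM, which would mean a 1.0-fold lower number from compound 3 to compound 4 (0.02 log units; within the scatter).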

Compound 4, concentration for 50% growth inhibition: 2900 nM
Estimate against measurement, compound 4: 1.1-fold (0.03 log units) below; low and high end bracket the measured number.
By their numbers in this assay, from the lowest: compounds 2, 3 and 4 (each within the scatter of the next); then compound 1.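

In this assay, chloro in place of methoxy gives a 1.0-fold higher number from compound 3 to compound 4 (0.02 log units; within the scatter), and chloro in place of bromo gives a 1.1-fold higher number from compound 2 to compound 4 (0.03 log units; within the scatter), so these three groups on this aromatic carbon cannot be told apart on this read-out. Within the data shown here, compound 1 and compound 4 both carry a chloro group and differ only in 2-chlorophenyl against 4-chlorophenyl, and a 5.2-fold lower number from compound 1 to compound 4 (0.71 log units; beyond the scatter) shows that the gap to compound 1 remains with the halogen unchanged, which the earlier steps, where the group changed as well, could not show. Nothing measured here gives a reason for either result.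

The compounds shown leave open whether an amine or a carboxylic acid on the same ring carbon would keep the number with those of compound 2, compound 3 and compound 4. They also leave open whether bromo or methoxy, placed where compound 1 holds its chloro, would give a number like that of compound 1.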